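The source may hold more compounds than are shown below. What is called first, only, known or untested is meant among the compounds shown, and "the series" means these compounds.

Compound 1 `O=C(/C=C/CNCCOc1ccc(Oc2c(-c3ccc(F)cc3)sc3cc(O)ccc23)cc1)N1CCCC1`: 7610 nM
Compound 2 `C=CC(=O)NCCOc1ccc(Oc2c(-c3ccc(F)cc3)sc3cc(O)ccc23)cc1`: 23000 nM
Compound 3 `C/C=C/C(=O)N1CC(Oc2ccc(Oc3c(-c4ccc(F)cc4)sc4cc(O)ccc34)cc2)C1`: 28000 nM

All three values come from a functional assay on MCF7 cells (Homo sapiens) for antiproliferative activity, read by CCK-8 assay, with a stated time of 48 h; on this read-out lower numbers stand for stronger inhibition and higher numbers for weaker inhibition. Compound 3 lies within the scatter of compound 2, and both stand above compound 1.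

The next change, to compound 4 `CNC(=O)/C=C/CNCCOc1ccc(Oc2c(-c3ccc(F)cc3)sc3cc(O)ccc23)cc1`, is 2-((3-(methylcarbamoyl)prop-2-en-1-yl)amino)ethyl in place of 1-((prop-1-en-1-yl)carbonyl)azetidin-3-yl on an oxygen on an aromatic ring on an oxygen on an aromatic ring. The measured 1.2-fold higher number from compound 2 to compound 3 (0.09 log units; within the scatter) stays within the scatter and offers little guide. The more relevant measured change is the modest 3.0-fold higher number from compound 1 to compound 2 (0.48 log units; beyond the scatter), since compound 4 regains a comparable chain on an amine nitrogen, and so a reversal of similar size is expected.

The expected change is a 3.1-fold lower number from compound 3 to compound 4 (0.49 log units; beyond the scatter), a modest move to a lower number. Compound 4 is estimated at 9000 nM, with an expected range of 4500 nM to 20000 nM for the measurement.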

Compound 4, half-maximal inhibitory concentration: 16100 nM
Beside the measured number, compound 4's estimate is 1.8-fold (0.25 log units) below it; the range from low to high includes it.
By their numbers in this assay, from the lowest: compound 1; then compounds 4, 2 and 3 (each within the scatter of the next).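

In this assay, methylamino in place of pyrrolidin-1-yl on a carbonyl carbon gives a 2.1-fold higher number from compound 1 to compound 4 (0.33 log units; beyond the scatter), so the group on that carbonyl carbon moves the number even with the rest of the chain unchanged. The other two changes give a 1.4-fold lower number from compound 2 to compound 4 (0.15 log units; within the scatter) and a 1.7-fold lower number from compound 3 to compound 4 (0.24 log units; within the scatter), both within the scatter, so the 2-((3-(methylcarbamoyl)prop-2-en-1-yl)amino)ethyl chain does not separate compound 4 from compound 2 or compound 3. Nothing available explains these steps. Open, going by these compounds, is how a dimethylamino or piperidin-1-yl group on that carbonyl carbon compares with pyrrolidin-1-yl and methylamino.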